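Dechlorination of a stable series: what to expect for compound 4

This account rests on a few compounds, and the source may have more. Where it says the series, first, only, none or still open, it means among the compounds named here.

Compound 1, `COc1ccc(-c2c(C)nc3c(N4CC[C@@H](NC(C)=O)C4)cc(Cl)nn23)cc1OC`: in an ADME assay on microsomes from liver (Mus musculus) for metabolic stability, read by LC-MS, with NADPH named in the record, with a stated time of 60 min, tested at 1 uM, in the absence of a further agent (on this read-out higher numbers stand for a more stable compound and lower numbers for a less stable compound), compound 1 gives > 95%, a limit of the assay.
Compound 2, `COc1ccc(-c2c(C)nc3c(N4CC[C@@H](NS(=O)(=O)c5ccccc5)C4)cc(C)nn23)cc1OC`: in this assay compound 2 gives > 95%, a limit of the assay.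
Compound 3, `COc1ccc(-c2c(C)nc3c(N4CC[C@@H](NS(=O)(=O)c5ccc(Cl)cc5)C4)cc(C)nn23)cc1OC`: in this assay compound 3 gives > 95%, a limit of the assay.

None of these three values is a number; each is a limit, as the limit of > 95% in this assay, at which 3 of the 3 values shown sit, states. Compound 2 and compound 3 differ by hydrogen in place of chloro on an aromatic carbon, and the step that the two limits leave unreadable from compound 3 to compound 2. Compound 4, `COc1ccc(-c2c(C)nc3c(N4CC[C@@H](NC(C)=O)C4)ccnn23)cc1OC`, is not yet measured in this assay and differs from compound 1 by hydrogen in place of chloro on an aromatic carbon. The difference between the cores of compound 1 and compound 3 is not broken down here. The change from compound 1 to compound 4 is the same kind of change as that from compound 3 to compound 2, but not the same: in one it sits on a six-membered aromatic ring of carbon only, para to a large group, in the other on a six-membered aromatic ring with 2 nitrogen, part of a fused or bridged system of two rings, next to the ring nitrogen. Because the limit of > 95% in this assay, at which 3 of the 3 values shown sit, holds every measured value at the ceiling, the step is expected to be small, a number at least 5 percentage points lower from compound 1 to compound 4 (that floor lies within the scatter). Compound 4 is therefore estimated at 90%, between 70% and 97%, in this assay.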

Compound 4, percent of the compound remaining: > 95%
Compound 4 gave a limit, no number (the forecaster's own chance of this, stated with the estimate: 55%); at least 5 percentage points between middle value and limit.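

No step can be read between compound 1 and compound 4, because both stand at a limit: the limit of > 95% in this assay, at which 4 of the 4 values shown sit. The compounds shown leave open whether hydrogen in place of chloro changes the percent remaining at all, and by how much.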